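Swapping a Fluorinated Ketone for a Methylpyridine Arm

The source may hold more compounds than are shown below. What is called first, only, known or untested is meant among the compounds shown, and "the series" means these compounds.

Measured so far:
compound 1, `CC(=O)c1coc(C(=O)CCCCCCc2ccccc2)n1`: 123 nM
compound 2, `O=C(CCCCCCc1ccccc1)c1ncc(C(=O)C(F)(F)F)o1`: 1820 nM
compound 3, `O=C(CCCCCCc1ccccc1)c1ncc(-c2ccc(C(=O)C(F)(F)F)cc2)o1`: > 10000 nM

All three were tested in an assay on HEK-293T cells for inhibition of diacylglycerol lipase-alpha (Homo sapiens), read by colorimetric assay; a lower number here means a stronger inhibitor, a higher number a weaker inhibitor. Compound 2 holds the higher of the two actual numbers, so it is the weaker inhibitor of that pair; compound 1 sits well below it, and the gap between them is beyond the usual scatter of repeated measurements. For compound 3 the reading is not a number but a limit, namely (the limit of > 10000 nM in this assay, at which 1 of the 3 values shown sits).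

The next compound is compound 4, `Cc1ccc(-c2cnc(C(=O)CCCCCCc3ccccc3)o2)nc1`. It differs from compound 2 in one place: 5-methylpyridin-2-yl in place of (trifluoromethyl)carbonyl on an aromatic carbon. The carbonyl bearing trifluoromethyl is gone, and a six-membered aromatic ring with one nitrogen, carrying a methyl, takes its spot on the shared core.

Among the measured compounds shown here, no measured pair shows this particular exchange, so the size of the step can only be guessed. The expectation is a moderate move toward a lower number in this assay, that is toward a somewhat stronger inhibitor, but with wide uncertainty. Compound 4 is estimated at 500 nM, with a likely range from 100 nM to 3000 nM. That estimate implies the step of a 3.6-fold lower number from compound 2 to compound 4 (0.56 log units; beyond the scatter).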

Compound 4, half-maximal inhibitory concentration: > 10000 nM
Compound 4: a limit, no number (the forecaster's own chance of this, stated with the estimate: 10%); at least 20-fold (1.30 log units) between middle value and limit.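

Placing 5-methylpyridin-2-yl in place of (trifluoromethyl)carbonyl, on the aromatic carbon next to the ring oxygen, weakens inhibition in this assay by an at least 5.4-fold higher number from compound 2 to compound 4 (0.73 log units; beyond the scatter) and gives the first single-place comparison in this small set. It shows that this position is sensitive to what it carries, and that an aromatic ring with a methyl, although similar in size to the group it replaces, does not restore inhibition here. Compound 4 gives a limit and not a number, the same limit as compound 3: the limit of > 10000 nM in this assay, at which 2 of the 4 values shown sit.

From the compounds shown here alone, the exchange removes the carbonyl and adds the ring at once, so these compounds cannot separate the loss of the one from the arrival of the other, and the full size of the step stays unknown. A carboxylic acid, a nitrile or an amine on this same aromatic carbon, or an unsubstituted pyridine ring without the methyl, would help show which features this position tolerates and whether any group here can match the inhibition seen with a carbonyl.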